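Charged chain-end variants on the shared core

The source may report more compounds than this note shows. Statements on the series, on what has been measured and on what is new or still open speak of the compounds shown alone.

Within the series built on the shared core, compound 1 `CN(C)c1ccc2c(=O)c(C(=O)Nc3cc(F)cc(F)c3)cn(-c3ccc(OCCCCCCC[N+]45CCN(CC4)CC5)cc3F)c2n1` is the reference point. In an assay on LX2 cells for inhibition of COL1A1 promoter (Homo sapiens), read by a luciferase reporter, with a stated time of 24 h, tested at 20 uM (a lower number here means a weaker effect, a higher number a stronger effect of the compound at the concentration tested), compound 1 gives 9.02%, a small read-out at the single concentration tested. Compound 2 `CC[N+]1(CCCCCCCOc2ccc(-n3cc(C(=O)Nc4cc(F)cc(F)c4)c(=O)c4ccc(N(C)C)nc43)c(F)c2)CCCCC1` is the closest measured neighbour of the unmeasured analogue. Compound 2 in this assay is reported only as "not active" (no number reported), so no number stands for it and its place relative to compound 1 cannot be put in figures beyond both sitting at the low end of the scale. Among the measured compounds shown here, compound 3 `CN1CC[N+](C)(CCCCCCCOc2ccc(-n3cc(C(=O)Nc4cc(F)cc(F)c4)c(=O)c4ccc(N(C)C)nc43)c(F)c2)CC1` is the next variant of this pair. a group of 8 heavy atoms (6 carbon, 2 nitrogen; one six-membered non-aromatic ring with 2 hetero atoms) in place of a group of 8 heavy atoms (7 carbon, 1 nitrogen; one six-membered non-aromatic ring with 1 hetero atom), on a saturated chain carbon, seven bonds along the chain from an oxygen on an aromatic ring No step between two measured compounds is known for this change, so the expectation rests on the two neighbours alone: both show little or no effect, and nothing in the measured pair points to a jump. The step from compound 2 to compound 3 in this assay is therefore expected to be small, without a clear direction beyond the scatter. Compound 3 in this assay is expected to give about 8%, with a range from 0% to 20%.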

Compound 3, a percentage reported as inhibition, at one concentration (the size of the read-out at that concentration, not a potency): "not active" (no number reported)
Nothing numeric was reported for compound 3, and the estimate cannot be compared.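

In this assay compound 2 and compound 3 are both reported only as not active, without a number, so no step can be read between them. Compound 1 gives 9.02% in this read-out. Left open is whether any other chain-end group on the shared core gives a stronger effect. No measured property shown bears on this result.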